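A few compounds are considered here, and "the series" means these few. Any claim that something is new, unique, unknown or untested is made for them only; others in the source may bear on it.

Compound 1 `N#Cc1ccc(-c2cnc3[nH]cc(-c4nnc(-c5ccc(F)cc5)o4)c(=O)c3c2)cc1` gives 10.2% in a functional assay on HCT-116 cells (Homo sapiens) for inhibition, read by MTT assay, with a stated time of 24 h, tested at 2.5 uM; on this read-out higher numbers stand for more inhibition of growth at the one concentration tested and lower numbers for less inhibition of growth.
Compound 2 `CS(=O)(=O)c1ccc(-c2cnc3[nH]cc(-c4nnc(-c5ccncc5)o4)c(=O)c3c2)cc1` gives 2.64% in this assay.
Compound 3 `N#Cc1ccc(-c2cnc3[nH]cc(-c4nnc(-c5ccc(Cl)cc5)o4)c(=O)c3c2)cc1` gives 13.7% in this assay.

Compound 2 stands lowest of the three numbers; its gap to compound 1 lies within the scatter, while compound 3 lies beyond it. Compound 4 `Cc1cccc(-c2nnc(-c3c[nH]c4ncc(-c5ccc(S(C)(=O)=O)cc5)cc4c3=O)o2)c1` differs from compound 2 by 3-methylphenyl in place of pyridin-4-yl on an aromatic carbon. For the measured compounds named here, the only measured single-point step, a number 3.5 percentage points higher from compound 1 to compound 3 (within the scatter), concerns a halogen swap on another ring and bears little on this change. Compounds 1 and 3, which carry carbon-only rings at this position, give higher numbers than compound 2, but they also differ from it elsewhere, so the comparison is indirect. A modest rise is therefore expected, with an estimated step of a number 5.4 percentage points higher from compound 2 to compound 4 (within the scatter). Compound 4 is estimated at 8%, between -2% and 20%.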

Compound 4, percent growth inhibition at one concentration: 8.13%
Beside the measured number, compound 4's estimate is 0.1 percentage points below it; the range from low to high includes it.
By their numbers in this assay, from the lowest: compounds 2, 4, 1 and 3 (each within the scatter of the next, the first and the last beyond it).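

For the compounds shown here, replacing pyridin-4-yl with 3-methylphenyl at this position, with the rest of compound 2 unchanged, gives the first direct reading of this change: in this assay it yields a number 5.5 percentage points higher from compound 2 to compound 4 (within the scatter). Removing the ring nitrogen and adding the methyl group therefore does not separate the two compounds on this read-out. Nothing shown here accounts for the step.

On these data alone, it remains open whether an amine or a carboxylic acid on this aromatic ring would separate from compound 2. The same question stands for a longer alkyl chain in place of the ring.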